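Solubility notes: pyridinylmethyl variant of compound 1

The source may report more compounds than this note shows. Statements on the series, on what has been measured and on what is new or still open speak of the compounds shown alone.

Compound 1 `COc1cccc(NC(=O)c2nnn(Cc3cc(C)on3)c2N)c1` gives 174000 nM in a physicochemical assay for solubility, read by nephelometry, at pH 7.4 (on this read-out higher numbers stand for higher solubility and lower numbers for lower solubility), the lower of the two numbers shown; its nearest neighbour, compound 3 `COc1cccc(NC(=O)c2nnn(Cc3ccc(C#N)cc3)c2N)c1`, gives 216000 nM, and the step of a 1.2-fold higher number from compound 1 to compound 3 (0.09 log units; within the scatter) lies within the scatter. Compound 2 `COc1cccc(NC(=O)c2nnn(Cc3ccc(SC)cc3)c2N)c1` reaches only a limit in this assay, < 12000 nM. The step of an at least 14-fold lower number from compound 1 to compound 2 (1.16 log units; beyond the scatter) is large. Compound 4 `COc1cccc(NC(=O)c2nnn(Cc3ccncc3)c2N)c1` differs from compound 1 by pyridin-4-yl in place of 5-methyl-1,2-oxazol-3-yl on a saturated chain carbon bound to an aromatic nitrogen. Both measured steps bear on this change, since each swaps the same group on the same carbon: a 1.2-fold higher number from compound 1 to compound 3 (0.09 log units; within the scatter) was within the scatter and an at least 14-fold lower number from compound 1 to compound 2 (1.16 log units; beyond the scatter) was a large drop. The entering ring is aromatic and carries one acceptor, as the leaving one did, so no step beyond the scatter is expected, a 1.0-fold higher number from compound 1 to compound 4 (0.01 log units; within the scatter). Compound 4 is estimated at 180000 nM, between 90000 nM and 360000 nM.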

Compound 4, solubility: < 12000 nM
Compound 4 was reported as a limit (the forecaster's own chance of this, stated with the estimate: 5%); at least 15-fold (1.17 log units) between middle value and limit.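

In this assay compound 4 stands at a limit, and both readable steps are large: an at least 14-fold lower number from compound 1 to compound 4 (1.16 log units; beyond the scatter) and an at least 18-fold lower number from compound 3 to compound 4 (1.25 log units; beyond the scatter). Exchanging one aromatic ring for another with the same count of heavy atoms, on a saturated chain carbon bound to an aromatic nitrogen, is therefore not a neutral change in this series. The step between compound 2 and compound 4 cannot be read, because both values are limits: the limit of < 12000 nM in this assay, at which 2 of the 4 values shown sit.

From the compounds shown here alone, how far compound 4 lies beyond its limit stays open. Also open, going by these compounds, is how a pyridin-3-yl ring, a morpholine or a carboxylic acid would read at this place.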